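The source may report more compounds than this note shows. Statements on the series, on what has been measured and on what is new or still open speak of the compounds shown alone.

In an ADME assay on cells (Astrocyte, Homo sapiens) for cytotoxicity, read by WST assay, with a stated time of 72 h (on this read-out higher numbers stand for weaker inhibition and lower numbers for stronger inhibition), compound 1 `O=C(Nc1ccc(Cl)c(Cl)c1)Nc1cc2ncncc2cc1OCc1ccccc1F` gives 3900 nM. Compound 2 `O=C(Nc1ccccc1F)Nc1cc2ncncc2cc1OCc1ccccc1` gives > 10000 nM, which is a limit of the assay and not a number. Compound 3 `O=C(Nc1ccccc1F)Nc1cc2ncncc2cc1OCc1ccccc1F` differs from compound 2 by fluoro in place of hydrogen on an aromatic carbon, with fluoro in place of hydrogen on an aromatic carbon, so that benzyloxy becomes (2-fluorobenzyl)oxy. Among the measured compounds shown here, compound 1 carries that same group, but no measured pair isolates the change. Little or nothing beyond the scatter is therefore expected in this assay, with any shift towards stronger inhibition. The estimated step runs an at least 1.1-fold lower number from compound 2 to compound 3 (0.04 log units; that floor lies within the scatter). For compound 3, the expected value is 9000 nM, within an estimated range of 4000 nM to 20000 nM.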

Compound 3, half-maximal inhibitory concentration: 10000 nM
For compound 3 the middle estimate is 1.1-fold (0.05 log units) below the measured one; the measured number falls inside the stated range.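

In this assay the change from 3,4-dichlorophenyl to 2-fluorophenyl on the amide-type nitrogen gives a 2.6-fold higher number from compound 1 to compound 3 (0.41 log units; beyond the scatter) with (2-fluorobenzyl)oxy held the same. Among the compounds shown here, this is the first readable step, and it lies beyond the scatter. Fluoro in place of hydrogen on the benzyloxy ring gives a number no higher from compound 2 to compound 3 (the limit leaves the size open). The size of this step cannot be read, since compound 2 stands at a limit of the assay and not at a number: the limit of > 10000 nM in this assay, at which 1 of the 3 values shown sits.

As far as these compounds go, it remains open whether a single chloro on the phenyl ring would carry the step, or how a methoxy in place of the fluoro would read.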